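A few compounds are considered here, and "the series" means these few. Any claim that something is new, unique, unknown or untested is made for them only; others in the source may bear on it.

Measured compounds:
- compound 1 `COc1cc(Oc2cccc(Nc3ccccc3)c2)cc(OC)c1CNCCNC(C)=O`: 5090 nM
- compound 2 `COc1cc(Oc2cccc(Nc3ccccc3)c2)cc(OC)c1CNCc1ccc(C)cc1`: 5400 nM
- compound 3 `COc1cc(Oc2cccc(Nc3ccccc3)c2)cc(OC)c1CNCc1ccc(O)cc1`: 3430 nM

In a functional assay on HCT-15 cells (Homo sapiens) for inhibition, read by MTT assay, with a stated time of 72 h (on this read-out lower numbers stand for stronger inhibition and higher numbers for weaker inhibition), compound 1 gives 5090 nM and stands second highest of the three numbers, with compound 2 nearest and compound 3 furthest, both within the scatter. Compound 4 `COc1cc(Oc2cccc(Nc3ccccc3)c2)cc(OC)c1CNCc1ccc(Br)cc1` has not been measured. It differs from compound 1 in one place: 4-bromophenyl in place of acetamidomethyl on a saturated chain carbon bound to an amine nitrogen. For the measured compounds named here, two measured steps bear on this change, both replacing acetamidomethyl by a substituted phenyl at the same place: a 1.1-fold higher number from compound 1 to compound 2 (0.03 log units; within the scatter) and a 1.5-fold lower number from compound 1 to compound 3 (0.17 log units; within the scatter). Neither leaves the scatter, and the step of a 1.6-fold lower number from compound 2 to compound 3 (0.20 log units; within the scatter) shows that swapping the group on that aromatic carbon also stays within it. The step to compound 4 is therefore expected to be a 1.2-fold lower number from compound 1 to compound 4 (0.07 log units; within the scatter), with no change beyond the scatter in this assay. Compound 4 is estimated at 4300 nM, with a range from 1700 nM to 11000 nM.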

Compound 4, half-maximal inhibitory concentration: 5410 nM
Compound 4: middle estimate off by 1.3-fold (0.10 log units), on the low side, and the stated range covers the measured number.
By their numbers in this assay, from the lowest: compounds 3, 1, 2 and 4 (each within the scatter of the next).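

In this assay, 4-bromophenyl in place of acetamidomethyl again gives no change beyond the scatter (a 1.1-fold higher number from compound 1 to compound 4 (0.03 log units; within the scatter)), so all three substituted phenyl groups at this position now stay within it. On the aromatic carbon, bromo and methyl give the same number (a 1.0-fold higher number from compound 2 to compound 4 (0.00 log units; within the scatter)), and bromo also stays within the scatter of hydroxy (a 1.6-fold higher number from compound 3 to compound 4 (0.20 log units; within the scatter)), so none of these three groups separates from the others there. No measurement at hand accounts for this flat picture.

The compounds shown leave open whether a carboxylic acid or an amine on that aromatic carbon, or a 2-phenylethyl group in place of the benzyl, would move the number beyond the scatter. Also open, on these data alone, is how an unsubstituted benzyl or a pyridine ring in place of the phenyl would read.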